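This account rests on a few compounds, and the source may have more. Where it says the series, first, only, none or still open, it means among the compounds named here.

Measured so far:
- compound 1, `Cc1ccccc1-n1cc(-c2ccc(NS(=O)(=O)c3c[nH]c(=O)[nH]c3=O)cc2)nn1`: in an ADME assay on GES1 cells (Homo sapiens) for cytotoxicity, read by MTT assay, with a stated time of 24 h (on this read-out higher numbers stand for lower toxicity in this test and lower numbers for higher toxicity in this test), compound 1 is recorded as "not toxic" (no number reported).
- compound 2, `O=c1[nH]cc(S(=O)(=O)Nc2ccc(-c3cn(-c4ccc(F)cc4)nn3)cc2)c(=O)[nH]1`: in this assay compound 2 gives > 100000 nM, which is a limit of the assay and not a number.

Compound 2 therefore stands at the limit of > 100000 nM in this assay, at which 1 of the 2 values shown sits, with no single number to place it against. Among the measured compounds shown here, the only other entry, compound 1, carries a qualitative result rather than a number, so no measured step exists and no comparison between the two can be drawn beyond the fact that neither shows a numerical half-maximal cytotoxic concentration.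

Compound 3, `O=c1[nH]cc(S(=O)(=O)Nc2ccc(-c3cn(-c4ccc(Cl)cc4)nn3)cc2)c(=O)[nH]1`, is the next compound to go into this assay. It differs from compound 2 by chloro in place of fluoro on an aromatic carbon.

For the measured compounds named here, no measured step is available to size this change. The expectation is that the step that the limit leaves unreadable from compound 2 to compound 3 stays within the usual scatter, with no direction to it, and that compound 3 most likely returns a limit again. On that basis compound 3 is estimated at 120000 nM, with a range from 40000 nM to 400000 nM.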

Compound 3, half-maximal cytotoxic concentration: 23300 nM
For compound 3 the middle estimate is 5.2-fold (0.71 log units) above the measured one, outside the stated range (below it).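

In this assay, the change from 4-fluorophenyl to 4-chlorophenyl gives an at least 4.2-fold lower number from compound 2 to compound 3 (0.63 log units; beyond the scatter), so exchanging one halogen for another on this aromatic carbon, para to a large group, is enough to move the read-out towards higher toxicity in this test. Among the compounds shown here, compound 3 gives 23300 nM, the first single number and the only fixed point so far for judging further changes at this position. The step remains a minimum and its true size is unknown, with compound 2 at the end that is a limit of the assay and not a number: the limit of > 100000 nM in this assay, at which 1 of the 3 values shown sits.

The compounds shown leave open whether bromo, methoxy or an amine on the same carbon would bring the number down further, hold it near that of compound 3, or return it to the limit, and whether the shift belongs to chloro alone or to any group other than fluoro at this position. Steps involving compound 1, recorded as "not toxic" (no number reported), cannot be read, so its place relative to the other two compounds remains open.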